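This account rests on a few compounds, and the source may have more. Where it says the series, first, only, none or still open, it means among the compounds named here.

Three compounds that share one core and differ only on an amine nitrogen in a ring were tested in a functional assay on HT-29 cells (Homo sapiens) for inhibition, read by sulforhodamine B assay; on this read-out lower numbers stand for stronger inhibition and higher numbers for weaker inhibition. Compound 1 `COC(=O)CC/C(C)=C/Cc1c(OC)c(C)c2c(c1OCC#CCN1CCN(c3ccccc3F)CC1)C(=O)OC2`, carrying 2-fluorophenyl there, gives > 50000 nM, which is a limit and not a number. Compound 2 `COC(=O)CC/C(C)=C/Cc1c(OC)c(C)c2c(c1OCC#CCN1CCN(c3ccc(O)cc3)CC1)C(=O)OC2`, carrying 4-hydroxyphenyl, gives > 50000 nM, again a limit. Compound 3 `COC(=O)CC/C(C)=C/Cc1c(OC)c(C)c2c(c1OCC#CCN1CCN(Cc3ccc(Cl)cc3)CC1)C(=O)OC2`, carrying 4-chlorobenzyl, gives > 50000 nM, also a limit. Compound 3 therefore has no numerical position and sits with the other two at the limit of > 50000 nM in this assay, at which 3 of the 3 values shown sit.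

Compound 4 `COC(=O)CC/C(C)=C/Cc1c(OC)c(C)c2c(c1OCC#CCN1CCN(c3ccc(C)cc3)CC1)C(=O)OC2` has 4-methylphenyl in place of 4-chlorobenzyl on the same nitrogen: 4-methylphenyl in place of 4-chlorobenzyl on an amine nitrogen in a ring. The closest measured precedents are a step that the two limits leave unreadable from compound 1 to compound 3 and a step that the two limits leave unreadable from compound 2 to compound 3, which also exchange a substituted phenyl and 4-chlorobenzyl at this place, while a step that the two limits leave unreadable from compound 1 to compound 2 changes only the substituted phenyl. None of these steps has a readable size, and none of the three groups moved the read-out off the limit. The expectation is therefore a number no higher from compound 3 to compound 4 (the limit leaves the size open), with no change beyond the scatter in either direction. Compound 4 is expected to remain inactive at the limit, with an estimated value of 50000 nM and an expected range from 20000 nM to 100000 nM.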

Compound 4, half-maximal inhibitory concentration: > 50000 nM
Compound 4: a limit, no number; the forecaster's own chance of this, stated with the estimate: 80%; the middle value sits exactly at the limit.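

In this assay compound 4 gives > 50000 nM, which is a limit and not a number. The steps to compound 4 from compound 1, compound 2 and compound 3 therefore cannot be read, and all four compounds stand together: the limit of > 50000 nM in this assay, at which 4 of the 4 values shown sit. The compounds shown leave open whether these groups on the amine nitrogen differ at all in this assay.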